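This account rests on a few compounds, and the source may have more. Where it says the series, first, only, none or still open, it means among the compounds named here.

Measured so far in an assay on HEK293 cells for inhibition of Steryl-sulfatase (Homo sapiens), tested at 0.1 uM; a lower number here means a weaker effect, a higher number a stronger effect of the compound at the concentration tested:
Compound 1, `CCN(Cc1ccccn1)c1ccc(C(=O)N2CCc3ccc(OS(N)(=O)=O)cc3C2)cc1`: 42.5%
Compound 2, `CCN(Cc1ccccc1)Cc1ccc(S(=O)(=O)N2CCc3ccc(OS(N)(=O)=O)cc3C2)cc1`: 10%

Of the compounds shown here, two built on the same core have been measured in this assay. Compound 1 gives 42.5% and stands highest of the two numbers; the nearest, compound 2, gives 10%, a gap beyond the usual scatter. Among the compounds with values here, compound 2 differs from compound 1 in more than one place, so the two numbers show only that compound 1 is the stronger of the pair, not which change is responsible.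

Compound 3, `CCCN(CCC)c1ccc(C(=O)N2CCc3ccc(OS(N)(=O)=O)cc3C2)cc1`, has not been measured. It differs from compound 1 in a single place:

dipropylamino in place of ethyl((pyridin-2-yl)methyl)amino on an aromatic carbon

The group that leaves carries a ring; the dipropylamino group that enters has none, and the position on the aromatic ring stays the same. Within the data shown here, no measured pair shows a step of this kind, so the expectation rests on compound 1 alone. The step of a number 7.5 percentage points lower from compound 1 to compound 3 (within the scatter) is expected to be small, somewhat downward, and close to the edge of the scatter. Compound 3 is therefore estimated at 35%, within a range from 15% to 55%.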

Compound 3, a percentage reported as inhibition, at one concentration (the size of the read-out at that concentration, not a potency): 36.6%
Beside the measured number, compound 3's estimate is 1.6 percentage points below it; the measured number falls inside the stated range.
By their numbers in this assay, from the lowest: compound 2; then compounds 3 and 1 (each within the scatter of the next).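

In this assay, putting dipropylamino in place of ethyl((pyridin-2-yl)methyl)amino on the aromatic carbon gives a number 5.9 percentage points lower from compound 1 to compound 3 (within the scatter) and so leaves no difference that can be told from ordinary repeat-to-repeat variation. Within the data shown here, this is the first single-place comparison in the set, and it shows that, for this pair on the shared core, a substituent with no ring can stand in for one carrying a six-membered aromatic ring without a readable change in the percentage at the concentration tested. No measured information explains why the two groups give such similar read-outs.

The pair cannot show whether the amine nitrogen at this position matters, which a comparison with a simple methoxy group or a plain hydrogen in the same place could address, or whether a closed amine such as piperidine, or a shorter one such as dimethylamino, would behave like dipropylamino. As far as these compounds go, each number also comes from a single concentration, so any difference in potency between the two compounds remains open, even though their read-outs lie within the scatter of each other.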